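Trimming an ethyl to a methyl on the shared core

The source may report more compounds than this note shows. Statements on the series, on what has been measured and on what is new or still open speak of the compounds shown alone.

Measured so far:
compound 1 `CC(=O)N[C@@H]1CCCc2c1cncc2N1C(=O)c2ccc(Cl)cc2[C@@H]1C` gives 81 nM
compound 2 `CC[C@@H]1c2cc(Cl)ccc2C(=O)N1c1cncc2c1CCC[C@H]2NC(C)=O` gives 334 nM

In an ADME assay on cells for inhibition of cytochrome P450 11B1, mitochondrial (Homo sapiens), read by HTRF (a lower number here means a stronger inhibitor, a higher number a weaker inhibitor), compound 2 stands at the highest of the two numbers; its nearest neighbour, compound 1, sits at a lower number, and that gap lies beyond the scatter. Compound 3 `CC(=O)N[C@@H]1CCCc2c1cncc2N1C(=O)c2ccc(Cl)cc2[C@H]1C` has not yet been measured. It differs from compound 2 by hydrogen in place of methyl on a saturated chain carbon bound to a saturated ring carbon, so the ethyl chain of compound 2 becomes a methyl. No step between measured compounds covers this change, so the expectation rests only on the two numbers shown. A modest downward step is expected, giving a somewhat stronger inhibitor, with a 2.4-fold lower number from compound 2 to compound 3 (0.38 log units; beyond the scatter) as the estimated size. Compound 3 is therefore expected to land at about 140 nM in this assay, within a range from 50 nM to 400 nM, that is, nearer to compound 1 than compound 2 is, though the true value could still fall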

Compound 3, half-maximal inhibitory concentration: 5140 nM
Compound 3: middle estimate off by 37-fold (1.56 log units), on the low side; measured number above the stated range.
By their numbers in this assay, from the lowest: compound 1; then compound 2; then compound 3.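

In this assay, the configuration at this saturated ring carbon turns out to matter a great deal, with a 63-fold higher number from compound 1 to compound 3 (1.80 log units; beyond the scatter). That gap is due to this single stereocentre, and the basis for saying so is this: the fact that compounds 1 and 3 differ only in the configuration as drawn. Trimming ethyl to methyl also proves far from a neutral change, since a 15-fold higher number from compound 2 to compound 3 (1.19 log units; beyond the scatter), so within this pair the shorter chain gives the weaker inhibitor.

The compounds shown do not tell whether a longer chain such as propyl, or a ring such as cyclopropyl, on this carbon would give a stronger or a weaker inhibitor. They also leave open how an ethyl chain would behave in the configuration that compound 1 carries at this carbon.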